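This account rests on a few compounds, and the source may have more. Where it says the series, first, only, none or still open, it means among the compounds named here.

Measured compounds:
Compound 1, `Cn1c(COc2cccc(C(=O)O)c2)nc2ccc(Oc3ccc4c(c3)CCC4)nc21`, 4.3 ug/mL
Compound 2, `Cn1c(COc2cccc(C(=O)O)c2)nc2cnc(Oc3ccc4c(c3)CCC4)cc21`, 70 ug/mL
Compound 3, `Cc1cccc(Oc2ccc3nc(COc4cccc(C(=O)O)c4)n(C)c3c2)n1`, 92 ug/mL

These three compounds were measured in a physicochemical assay for solubility, read by HPLC, measured as thermodynamic solubility, with a stated time of 4 h, at pH 6.8; a lower number here means a less soluble compound, a higher number a more soluble compound. In this assay compound 3 gives 92 ug/mL, the highest of the three numbers, yet compound 2 with 70 ug/mL lies within the scatter of it, so the two cannot be placed in order. Compound 1, at 4.3 ug/mL, sits far below both, beyond the scatter. For the measured compounds named here, no single-change pair is known among the measured compounds.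

Compound 4 is `Cc1cc(Cl)cnc1Oc1ccc2nc(COc3cccc(C(=O)O)c3)n(C)c2c1`, not yet measured. It differs from compound 3 in one place:
5-chloro-3-methylpyridin-2-yl in place of 6-methylpyridin-2-yl on an oxygen on an aromatic ring
Going by the values given here, the three measured compounds offer no direct precedent for this change. A chlorine added to the pyridine ring would, on general experience, be expected to lower the number in this assay, so the step from compound 3 to compound 4 is estimated as a moderate decrease, a 2.6-fold lower number from compound 3 to compound 4 (0.42 log units; beyond the scatter), somewhat beyond the scatter. Compound 4 is therefore expected to give about 35 ug/mL, with a range from 12 ug/mL to 90 ug/mL.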

Compound 4, solubility: 3.9 ug/mL
Compound 4: middle estimate off by 9.0-fold (0.95 log units), on the high side; measured number outside the range, below it.
By their numbers in this assay, from the lowest: compounds 4 and 1 (each within the scatter of the next); then compounds 2 and 3 (each within the scatter of the next).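

In this assay, for the compounds shown here, 5-chloro-3-methylpyridin-2-yl in place of 6-methylpyridin-2-yl gives a 24-fold lower number from compound 3 to compound 4 (1.37 log units; beyond the scatter), the first step in this set that can be read as a change in one place, and it is large. It shows that the number can shift widely with the group held on this oxygen, even though the hydrogen-bond donors, hydrogen-bond acceptors and net charge counted for the two groups stay the same. Nothing measured here accounts for the size of this step.

The step combines a new chlorine with a different placing of the methyl, and the compounds shown do not separate the two. They also leave open whether a pyridine bearing the methyl alone, or a nitrile or an amine where the chlorine stands, would stay nearer compound 3 or nearer compound 4.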